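A few compounds are considered here, and "the series" means these few. Any claim that something is new, unique, unknown or untested is made for them only; others in the source may bear on it.

Compound 1 `COc1ncc(-c2ccc3nccc(-c4ccc(C)cc4)c3c2)cc1NS(=O)(=O)c1ccc(F)cc1F` gives 67100 nM in a functional assay on U-87MG ATCC cells (Homo sapiens) for cytotoxicity, read by MTT assay, with a stated time of 72 h; on this read-out lower numbers stand for stronger inhibition and higher numbers for weaker inhibition.
Compound 2 `CCN(CC)Cc1ccc(-c2ccnc3ccc(-c4cnc(OC)c(NS(=O)(=O)c5ccc(F)cc5F)c4)cc23)cc1` gives 4890 nM in this assay.
Compound 3 `COc1ncc(-c2ccc3nccc(-c4ccc(CN5CCCC5)cc4)c3c2)cc1NS(=O)(=O)c1ccc(F)cc1F` gives 159 nM in this assay.

Among these three, compound 3 has the lowest number in this assay: the nearest is compound 2, as the step of a 31-fold lower number from compound 2 to compound 3 (1.49 log units; beyond the scatter) shows, and the furthest is compound 1, as a 420-fold lower number from compound 1 to compound 3 (2.63 log units; beyond the scatter) shows. Compound 4 `COc1ncc(-c2ccc3nccc(-c4ccc(CN5CCN(C(C)C)CC5)cc4)c3c2)cc1NS(=O)(=O)c1ccc(F)cc1F` has not yet been measured; it differs from compound 3 by 4-isopropylpiperazin-1-yl in place of pyrrolidin-1-yl on a saturated chain carbon bound to an aromatic carbon.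

The measured steps that bear on this change all sit at the same place on the shared core. Replacing hydrogen there gave a 14-fold lower number from compound 1 to compound 2 (1.14 log units; beyond the scatter) and a 420-fold lower number from compound 1 to compound 3 (2.63 log units; beyond the scatter), and exchanging one amine for another gave a 31-fold lower number from compound 2 to compound 3 (1.49 log units; beyond the scatter). Among the compounds with values here, those steps show that the choice of amine at this position can move the number by a large amount in either direction, but no step here involves a piperazine, so the direction for compound 4 cannot be read off directly. A step of moderate size, most likely toward a higher number, is expected for compound 4 in this assay, that is a 2.0-fold higher number from compound 3 to compound 4 (0.30 log units; within the scatter). The estimate for compound 4 in this assay is 320 nM, with a range from 80 nM to 1500 nM.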

Compound 4, half-maximal inhibitory concentration: 468 nM
Compound 4: the middle estimate sits 1.5-fold (0.17 log units) below what was measured, within the range that was stated.
By their numbers in this assay, from the lowest: compound 3; then compound 4; then compound 2; then compound 1.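

The 4-isopropylpiperazin-1-yl group, the first piperazine at this place, stays fairly close to pyrrolidin-1-yl in this assay: the change gives a 2.9-fold higher number from compound 3 to compound 4 (0.47 log units; beyond the scatter), a modest step, though one beyond the scatter. The same group still gives a 10-fold lower number from compound 2 to compound 4 (1.02 log units; beyond the scatter) and a 140-fold lower number from compound 1 to compound 4 (2.16 log units; beyond the scatter), so it ranks between pyrrolidin-1-yl and diethylamino and keeps most of the gain seen over hydrogen on the saturated chain carbon. Among the amines shown, both ring amines therefore give lower numbers than the open-chain diethylamino, with compound 3 lowest.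

Nothing available here explains why these amines differ. On these data alone, whether a morpholine, a piperidine or a piperazine without the isopropyl group would fall nearer compound 3 or compound 4 remains open.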